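Aryl sulfamate series: unmeasured diisopentyl analogue of compound 1

The source may hold more compounds than are shown below. What is called first, only, known or untested is meant among the compounds shown, and "the series" means these compounds.

Measured so far in an assay on HEK293 cells for inhibition of Steryl-sulfatase (Homo sapiens), tested at 0.1 uM; on this read-out lower numbers stand for a weaker effect and higher numbers for a stronger effect at the one concentration tested:
compound 1 `CN(C)CCN(CCN(C)C)c1ccc(C(=O)N2CCc3ccc(OS(N)(=O)=O)cc3C2)cc1` gives 3.8%
compound 2 `CCN(Cc1ccccc1)Cc1ccc(CN2CCc3ccc(OS(N)(=O)=O)cc3C2)cc1` gives 1%
compound 3 `NS(=O)(=O)Oc1ccc2c(c1)CN(C(=O)c1ccc(N3CCC(N4CCCCC4)CC3)cc1)CC2` gives 8.5%

All three numbers are small and the whole set lies within the usual scatter of repeated measurements, so nothing separates the compounds on this read-out. Compound 1 sits in the middle of the three, and the values of compound 2 and compound 3 both fall within the usual scatter of it. Among the measured compounds shown here, no two of the measured compounds differ in only one place, so no single-point step is available.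

The next compound, compound 4 `CC(C)CCN(CCC(C)C)c1ccc(C(=O)N2CCc3ccc(OS(N)(=O)=O)cc3C2)cc1`, differs from compound 1 in one place: diisopentylamino in place of bis(2-(dimethylamino)ethyl)amino on an aromatic carbon. The shared core and the amide link are kept. For the measured compounds named here, nothing measured so far shows any change in this assay, and the three structures with rather different amine substituents all give near-zero inhibition. The step expected in this assay from compound 1 to compound 4 is therefore none beyond the scatter, with no preferred direction, estimated as a number 1.2 percentage points higher from compound 1 to compound 4 (within the scatter). Compound 4 is expected to give 5%, with a range from 0% to 18%.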

Compound 4, a percentage reported as inhibition, at one concentration (the size of the read-out at that concentration, not a potency): 47%
Estimate against measurement, compound 4: 42 percentage points below, and the stated range ends below it.
By their numbers in this assay, from the lowest: compounds 2, 1 and 3 (each within the scatter of the next); then compound 4.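

In this assay, among the compounds shown here, replacing bis(2-(dimethylamino)ethyl)amino with diisopentylamino gives a number 43.2 percentage points higher from compound 1 to compound 4 (beyond the scatter) and is the first single-place step, showing that the group on this aromatic carbon, para to a large group, can strongly shift the read-out while the shared core and amide link stay fixed. The step does not follow a change in heavy-atom count: both groups carry 11 heavy atoms and no ring, while the composition moves from 8 carbon and 3 nitrogen to 10 carbon and 1 nitrogen. No available evidence bears on the reason for this step.

Still open, from the compounds shown here alone, is whether the step follows the loss of the dimethylamino ends or the arrival of the branched isopentyl chains, a question that an unbranched dipentylamino group at this place would address. Also open, going by these compounds, is whether a longer chain, such as dihexylamino, would raise or lower the read-out.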